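Replacing phenylcarbamoyl with (4-methylphenyl)sulfonyl on a stable compound

The compounds below may be only part of what the source reports. "The series", "measured", "known", "first", "only" and "open" are said of these compounds alone.

So far two compounds have been measured in an ADME assay on microsomes from liver (Homo sapiens) for metabolic stability, read by LC-MS, with NADPH named in the record, with a stated time of 60 min, tested at 1 uM, in the absence of a further agent; on this read-out lower numbers stand for a less stable compound and higher numbers for a more stable compound. In this assay compound 1 (`COc1ccc(-n2c(C)nc3c(N4CC[C@@H](NC(C)=O)C4)nc(C)nc32)cc1OC`) gives > 95%, which is a limit and not a number. In this assay compound 2 (`COc1ccc(-c2c(C)nc3c(N4CC[C@@H](NC(=O)Nc5ccccc5)C4)cc(C)nn23)cc1OC`) gives > 95%, which is likewise a limit and not a number. Compound 2 therefore stands at the limit of > 95% in this assay, at which 2 of the 2 values shown sit.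

Compound 3 (`COc1ccc(-c2c(C)nc3c(N4CC[C@@H](NS(=O)(=O)c5ccc(C)cc5)C4)cc(C)nn23)cc1OC`) departs from compound 2 in one place: (4-methylphenyl)sulfonyl in place of phenylcarbamoyl on an amine nitrogen. In words, (4-methylphenyl)sulfonyl takes the place of phenylcarbamoyl on an amine nitrogen, while the rest of the structure stays the same. For the measured compounds named here, no measured pair of compounds differs in one place, so the data offer no direct guide to the size of this change.

The expected step of a number at least 7 percentage points lower from compound 2 to compound 3 (that floor lies within the scatter) is a small one downward, and it may well not go beyond the scatter. That expectation starts from compound 2, whose > 95% is a limit. For compound 3 the estimated value in this assay is 88%, with an expected range from 65% to 99%.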

Compound 3, percent of the compound remaining: > 95%
Compound 3: a limit, no number; the forecaster's own chance of this, stated with the estimate: 40%; at least 7 percentage points between middle value and limit.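

In this assay compound 3 gives > 95%, which is a limit and not a number. For the compounds shown here, compound 2 also sits at a limit, so no step between compound 2 and compound 3 can be read. The compounds shown leave open whether (4-methylphenyl)sulfonyl in place of phenylcarbamoyl on an amine nitrogen alters this read-out at all.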